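The source may report more compounds than this note shows. Statements on the series, on what has been measured and on what is new or still open speak of the compounds shown alone.

In an ADME assay on CCRF-HSB-2 cells (Homo sapiens) for cytotoxicity, with a stated time of 7 days (on this read-out higher numbers stand for lower toxicity in this test and lower numbers for higher toxicity in this test), compound 3 (`CSc1nc(N)nc2c1ncn2/C=C1/CC1(CO)CO`) gives > 100000 nM, which is a limit. Compound 2 (`Nc1nc(NC2CC2)c2ncn(/C=C3/CC3(CO)CO)c2n1`) gives > 20000 nM, also a limit. Compound 1 (`CC(C)CSc1nc(N)nc2c1ncn2/C=C1/CC1(CO)CO`) gives a true number, 60000 nM.

Compound 4 (`CCCCCCSc1nc(N)nc2c1ncn2/C=C1/CC1(CO)CO`) has pentyl in place of hydrogen on a saturated chain carbon bound to a sulfur, that is, methylsulfanyl to hexylsulfanyl: pentyl in place of hydrogen on a saturated chain carbon bound to a sulfur. Going by the values given here, the only step bearing on this is an at least 1.6-fold higher number from compound 1 to compound 3 (0.22 log units; that floor lies within the scatter), a change at the same chain carbon that shortens the chain. Neither a step that the limit leaves unreadable from compound 1 to compound 2 nor a step that the two limits leave unreadable from compound 2 to compound 3 offers a size. That weak evidence points to a lower number, meaning higher toxicity, on lengthening the chain. The expected step is an at least 3.3-fold lower number from compound 3 to compound 4 (0.52 log units; beyond the scatter). For compound 4 the estimated value is 30000 nM, with an expected range from 8000 nM to 100000 nM.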

Compound 4, half-maximal cytotoxic concentration: 60000 nM
The estimate for compound 4 lay 2.0-fold (0.30 log units) below the measured number; the measured number falls inside the stated range.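

On a saturated chain carbon bound to a sulfur, hexylsulfanyl gives a true number in this assay, with an at least 1.6-fold lower number from compound 3 to compound 4 (0.22 log units; that floor lies within the scatter). Compound 3 gives > 100000 nM, which is a limit. Set against isobutylsulfanyl, hexylsulfanyl shows no change at the digits printed from compound 1 to compound 4 (within the scatter), so these two chains are not told apart in this test.

The step from compound 2 cannot be read. Still open, going by these compounds, is whether a longer chain such as decylsulfanyl, or an amine at the end of the hexyl chain, would move the number beyond the scatter.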